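Trimming the Benzyl Substituent Down to Ethyl

The compounds below may be only part of what the source reports. "The series", "measured", "known", "first", "only" and "open" are said of these compounds alone.

Among the compounds with values here, compound 2 `O=C(O)CN1C(=O)/C(=C/c2nc3ccccc3n2Cc2ccc(Cl)cc2)SC1=S` is the only compound here with a number rather than a limit in a functional assay on HeLa cells (Homo sapiens) for cytotoxicity, read by MTT assay, with a stated time of 48 h (a higher number here means a weaker inhibitor, a lower number a stronger inhibitor), where compound 2 gives 8720 nM. Compound 1 `O=C(O)CN1C(=O)/C(=C/c2nc3ccccc3n2Cc2ccc(Br)cc2F)SC1=S` reaches only a limit in this assay, giving > 50000 nM, which is the assay's limit (the limit of > 50000 nM in this assay, at which 1 of the 2 values shown sits). Within the data shown here, the one measured step, an at least 5.7-fold lower number from compound 1 to compound 2 (0.75 log units; beyond the scatter), shows that the group on the saturated chain carbon bound to the aromatic nitrogen matters. Compound 3 `CCn1c(/C=C2\SC(=S)N(CC(=O)O)C2=O)nc2ccccc21` goes further: methyl in place of 4-chlorophenyl on a saturated chain carbon bound to an aromatic nitrogen. The measured step exchanges one substituted phenyl for another, whereas here the 4-chlorophenyl leaves altogether, so that step bears on the new change only loosely. With the ring gone, a weaker inhibitor is expected, and the expected step is a 2.9-fold higher number from compound 2 to compound 3 (0.46 log units; beyond the scatter). Compound 3 is therefore estimated to give about 25000 nM in this assay, somewhere between 8000 nM and 80000 nM, with a fair chance that only a limit is reported.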

Compound 3, half-maximal inhibitory concentration: 3520 nM
Beside the measured number, compound 3's estimate is 7.1-fold (0.85 log units) above it; the whole stated range lies above it.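

In this assay, methyl in place of 4-chlorophenyl on a saturated chain carbon bound to an aromatic nitrogen gives a 2.5-fold lower number from compound 2 to compound 3 (0.39 log units; beyond the scatter), so an aromatic ring on this carbon is not needed for a lower number, and here the ethyl of compound 3 outdoes the 4-chlorobenzyl of compound 2. The earlier step only exchanged one substituted phenyl for another, whereas an at least 14-fold lower number from compound 1 to compound 3 (1.15 log units; beyond the scatter) now sets the same small group against the second substituted phenyl as well. That step has only a lower bound, as compound 1 reaches a limit and not a number: the limit of > 50000 nM in this assay, at which 1 of the 3 values shown sits.

The compounds shown leave open how a longer chain such as butyl, or an amine or hydroxyl carried on the ethyl, would read at this position. They also leave open how an unsubstituted phenyl would compare with the 4-chlorophenyl.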